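A few compounds are considered here, and "the series" means these few. Any claim that something is new, unique, unknown or untested is made for them only; others in the source may bear on it.

Measured so far:
- Compound 1 `O=C1C=C(N2CCC2)C(=O)c2c1nc1n2[C@H]2OC[C@@H](O)[C@H]2OC1`: > 16000 nM
- Compound 2 `O=C1C(NC2CCCC2)=CC(=O)c2c1nc1n2[C@H]2OC[C@@H](O)[C@H]2OC1`: > 16000 nM
- Compound 3 `O=C1C=C(Nc2ccccc2F)C(=O)c2c1nc1n2[C@H]2OC[C@@H](O)[C@H]2OC1`: 2760 nM

In a functional assay on ECa-109 cells for inhibition, with ECa-109 cell line (Homo sapiens) as the target, read by sulforhodamine B assay (on this read-out higher numbers stand for weaker inhibition and lower numbers for stronger inhibition), compound 2 gives only a limit, > 16000 nM, and not a true number. It shares this with compound 1, as the limit of > 16000 nM in this assay, at which 2 of the 3 values shown sit, shows.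

Compound 4 `COc1ccccc1NC1=CC(=O)c2c(nc3n2[C@H]2OC[C@@H](O)[C@H]2OC3)C1=O` differs from compound 2 by 2-methoxyphenyl in place of cyclopentyl on an amine nitrogen. The closest guide is one measured change, an at least 5.7-fold lower number from compound 1 to compound 3 (0.76 log units; beyond the scatter), which put (2-fluorophenyl)amino in place of azetidin-1-yl. Among the compounds with values here, that step starts from a limit, and it is only one step, so its true size is unknown. A similar move towards stronger inhibition is expected here, and the expected change is an at least 3.5-fold lower number from compound 2 to compound 4 (0.55 log units; beyond the scatter). For compound 4 the estimate is 4500 nM, within a range of 1500 nM to 16000 nM.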

Compound 4, half-maximal inhibitory concentration: > 4000 nM
Compound 4: a limit, no number (the forecaster's own chance of this, stated with the estimate: 35%); the middle value does not contradict the limit.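

Compound 2 and compound 4 both give only limits, not true numbers, and the step between them cannot be read. The compounds shown leave open whether (2-methoxyphenyl)amino gives stronger inhibition than cyclopentylamino on the shared core.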